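Benzyl sulfide variation on a shared pyrrolopyrimidine-bearing core

The source may hold more compounds than are shown below. What is called first, only, known or untested is meant among the compounds shown, and "the series" means these compounds.

Measured in a functional assay on MGC-803 cells (Homo sapiens) for inhibition, read by MTT assay, with a stated time of 72 h; on this read-out higher numbers stand for weaker inhibition and lower numbers for stronger inhibition:
compound 1 `Cc1cc(N2CC[C@@H](C)[C@@H](N(C)c3ncnc4[nH]ccc34)C2)n2nc(SCc3ccc(C(F)(F)F)cc3)nc2n1`: 2680 nM
compound 2 `Cc1cc(N2CC[C@@H](C)[C@@H](N(C)c3ncnc4[nH]ccc34)C2)n2nc(SCC3CC3)nc2n1`: 9540 nM
compound 3 `Cc1cc(N2CC[C@@H](C)[C@@H](N(C)c3ncnc4[nH]ccc34)C2)n2nc(SCc3nc4ccccc4[nH]3)nc2n1`: 21200 nM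

Compound 2 stands second highest of the three numbers in this assay, with compound 3 nearest and compound 1 furthest from it. The unmeasured compound 4 `Cc1cc(N2CC[C@@H](C)[C@@H](N(C)c3ncnc4[nH]ccc34)C2)n2nc(SCc3ccc(F)c(Cl)c3)nc2n1` differs from compound 2 in one place: 3-chloro-4-fluorophenyl in place of cyclopropyl on a saturated chain carbon bound to a sulfur.

The step that bears most directly on this change is a 3.6-fold higher number from compound 1 to compound 2 (0.55 log units; beyond the scatter), where 4-(trifluoromethyl)phenyl was exchanged for cyclopropyl. Compound 4 reverses that direction, placing a substituted phenyl ring, 3-chloro-4-fluorophenyl, back onto the saturated chain carbon bound to the sulfur. The other steps caution against a simple rule: a 7.9-fold higher number from compound 1 to compound 3 (0.90 log units; beyond the scatter) and a 2.2-fold higher number from compound 2 to compound 3 (0.35 log units; beyond the scatter) show that 1H-benzimidazol-2-yl, also a ring, gave the highest number of the set. Compound 4 therefore cannot be assumed to match compound 1 exactly.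

Compound 4 is expected to give a lower number than compound 2, a step of about a 3.0-fold lower number from compound 2 to compound 4 (0.47 log units; beyond the scatter). The estimate for compound 4 in this assay is 3200 nM, within a range from 1300 nM to 8000 nM.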

Compound 4, half-maximal inhibitory concentration: 52000 nM
Beside the measured number, compound 4's estimate is 16-fold (1.21 log units) below it; the measured number lies above the stated range.
By their numbers in this assay, from the lowest: compound 1; then compound 2; then compound 3; then compound 4.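

In this assay, a substituted phenyl ring on this saturated chain carbon bound to a sulfur did not by itself bring a lower number: 3-chloro-4-fluorophenyl in place of cyclopropyl gave a 5.5-fold higher number from compound 2 to compound 4 (0.74 log units; beyond the scatter) and so moved the number upward. The two substituted phenyl rings instead mark the ends of the set, with a 19-fold higher number from compound 1 to compound 4 (1.29 log units; beyond the scatter) as the largest step at this place, so the ring's substituents separate these compounds, not the phenyl ring alone. 1H-benzimidazol-2-yl also no longer gives the highest number, given a 2.5-fold higher number from compound 3 to compound 4 (0.39 log units; beyond the scatter) in this series. No measurement shown accounts for this gap.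

Still open, as far as these compounds go, is how a plain phenyl ring, or one bearing only chlorine or only fluorine, would read here. Also open, from the compounds shown here alone, is whether a longer chain between the sulfur and the ring would change the order.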